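Closing the Amine: Piperidine in Place of Cyclopentylamine

A few compounds are considered here, and "the series" means these few. Any claim that something is new, unique, unknown or untested is made for them only; others in the source may bear on it.

The measured compounds, with their values in a functional assay on MGC-803 cells (Homo sapiens) for inhibition, read by sulforhodamine B assay; a lower number here means a stronger inhibitor, a higher number a weaker inhibitor:
compound 1, `Cc1ccc(NC2=CC(=O)c3nc4n(c3C2=O)[C@H]2OC[C@@H](O)[C@H]2OC4)cc1`, gives 1420 nM.
compound 2, `O=C1C=C(NCc2ccccc2)C(=O)c2c1nc1n2[C@H]2OC[C@@H](O)[C@H]2OC1`, gives 2670 nM.
compound 3, `O=C1C=C(NC2CCCC2)C(=O)c2c1nc1n2[C@H]2OC[C@@H](O)[C@H]2OC1`, gives > 8000 nM.

Compound 3 stands at the limit of > 8000 nM in this assay, at which 1 of the 3 values shown sits, which is a limit of this assay and not a number. It is the weakest of the three: from compound 1 the step of an at least 5.6-fold higher number from compound 1 to compound 3 (0.75 log units; beyond the scatter) and from compound 2 the step of an at least 2.9-fold higher number from compound 2 to compound 3 (0.47 log units; beyond the scatter) both lead to it, whereas a 1.9-fold higher number from compound 1 to compound 2 (0.27 log units; within the scatter) stays within the scatter.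

Compound 4, `O=C1C=C(N2CCCCC2)C(=O)c2c1nc1n2[C@H]2OC[C@@H](O)[C@H]2OC1`, differs from compound 3 by piperidin-1-yl in place of cyclopentylamino on a double-bonded ring carbon. Within the data shown here, every measured step exchanges the carbon part attached to the amine nitrogen and keeps the hydrogen on that nitrogen; none removes that hydrogen or closes the nitrogen into a ring, so no measured step bears directly on this change. Among the measured compounds shown here, what the numbers do show is that compound 3 already sits at the limit, and the change made here has no measured precedent. The expectation is therefore a value near or beyond the limit, with no step beyond the scatter predicted in either direction. Compound 4 is estimated at 10000 nM, between 4000 nM and 25000 nM, which means an expected step that the limit leaves unreadable from compound 3 to compound 4.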

Compound 4, half-maximal inhibitory concentration: > 8000 nM
Compound 4: no number, only a limit; the forecaster's own chance of this, stated with the estimate: 70%; the middle value lies beyond the limit too.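

Compound 4 gives only a limit of the assay in this assay, not a number, and compound 3 gives the same limit: the limit of > 8000 nM in this assay, at which 2 of the 4 values shown sit. What compound 4 adds is that closing the amine nitrogen into piperidin-1-yl, which leaves 0 hydrogen-bond donors on the group, does not yield a readable value at this double-bonded ring carbon, and the change gives an at least 2.9-fold higher number from compound 2 to compound 4 (0.47 log units; beyond the scatter) and an at least 5.6-fold higher number from compound 1 to compound 4 (0.75 log units; beyond the scatter). The step between compound 3 and compound 4 cannot be read, so these two groups cannot be ranked against each other, and the result shows only that both sit on the weak side of benzylamino and (4-methylphenyl)amino.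

The compounds shown leave open whether the hydrogen on the amine nitrogen matters in itself, as compound 4 loses that hydrogen while also differing from compound 1 and compound 2 in its carbon part. Methyl(4-methylphenyl)amino, with a methyl in place of that hydrogen on the group of compound 1, would put this question to a starting point with a readable number.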